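The source may report more compounds than this note shows. Statements on the series, on what has been measured and on what is new or still open speak of the compounds shown alone.

Among the compounds with values here, compound 3 `COc1cc(-c2cnn3cc(OC)c(N(C)C)nc23)ccn1` carries the highest of the three numbers so far: in an assay on isolated protein for inhibition of activin receptor type-2A (Homo sapiens), read by 33P incorporation, with a stated time of 20 min, in the presence of a further agent that is not named here (a higher number here means a weaker inhibitor, a lower number a stronger inhibitor), compound 3 gives 3000 nM. Compound 2 `COc1cc(-c2cnn3cc(OC)c(C(C)(C)O)nc23)ccn1` gives 2700 nM in this assay, and the two stand within the scatter of each other, as shown by a 1.1-fold higher number from compound 2 to compound 3 (0.05 log units; within the scatter). Compound 1 `CCc1nc2c(-c3ccnc(OC)c3)cnn2cc1OC` gives 960 nM in this assay and is the one that stands apart: both a 3.1-fold higher number from compound 1 to compound 3 (0.49 log units; beyond the scatter) and a 2.8-fold higher number from compound 1 to compound 2 (0.45 log units; beyond the scatter) are beyond the scatter, so ethyl on this aromatic carbon gave the lowest number of the three.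

The step to compound 4 `COc1cc(-c2cnn3cc(OC)c([C@H]4COC(C)(C)C4)nc23)ccn1` is a group of 7 heavy atoms (6 carbon, 1 oxygen; one five-membered non-aromatic ring with 1 hetero atom) in place of a group of 3 heavy atoms (2 carbon, 1 nitrogen; no ring), on an aromatic carbon. The measured steps that bear on it are the three exchanges at this same carbon: the move from ethyl to dimethylamino, modest and upward, and the move from 1-hydroxy-1-methylethyl to dimethylamino, within the scatter. A carbon-linked group returning in place of dimethylamino, larger than ethyl and ring-bearing, is expected to bring the number back toward that of compound 1 rather than beyond it, so a modest downward step is expected, a 2.3-fold lower number from compound 3 to compound 4 (0.36 log units; beyond the scatter). Compound 4 is therefore expected to give about 1300 nM in this assay, within a range of 450 nM to 3800 nM.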

Compound 4, half-maximal inhibitory concentration: 4100 nM
Compound 4: the middle estimate sits 3.2-fold (0.50 log units) below what was measured; the whole stated range lies below it.
By their numbers in this assay, from the lowest: compound 1; then compounds 2, 3 and 4 (each within the scatter of the next).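

In this assay, the ring-bearing group of compound 4 does not separate from dimethylamino (a 1.4-fold higher number from compound 3 to compound 4 (0.14 log units; within the scatter)) or from 1-hydroxy-1-methylethyl (a 1.5-fold higher number from compound 2 to compound 4 (0.18 log units; within the scatter)), so a carbon link at this aromatic carbon does not by itself restore the lower number of compound 1. Ethyl remains the only one of the four groups set apart (a 4.3-fold higher number from compound 1 to compound 4 (0.63 log units; beyond the scatter)), and the added ring and extra heavy atoms of compound 4 bring no gain over it. Nothing available here explains why ethyl stands apart from the other three groups.

Open, going by these compounds, is whether methyl, n-propyl or cyclopropyl at this carbon would match or fall below compound 1. Also open, on these data alone, is how the opposite stereoisomer of the ring in compound 4 would compare.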